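Tert-butyl to isopropyl on a prodrug ester

The source may hold more compounds than are shown below. What is called first, only, known or untested is meant among the compounds shown, and "the series" means these compounds.

Measured compounds:
compound 1 `CCOC(=O)C1=C(S[C@@H]2CN[C@H](C(=O)Nc3cccc(C(=O)OCC)c3)C2)[C@H](C)[C@@H]2[C@@H]([C@@H](C)OC(C)=O)C(=O)N12` gives 0%
compound 2 `CCOC(=O)C1=C(S[C@@H]2CN[C@H](C(=O)Nc3cccc(C(=O)OCC)c3)C2)[C@H](C)[C@@H]2[C@@H]([C@@H](C)OC(=O)CC)C(=O)N12` gives 0%
compound 3 `C[C@@H](O)[C@H]1C(=O)N2C(C(=O)O)=C(S[C@@H]3CN[C@H](C(=O)Nc4cccc(C(=O)OCOC(=O)C(C)(C)C)c4)C3)[C@H](C)[C@H]12` gives 0%

All three were tested in an ADME assay on a cell-free system (plasma, Rattus norvegicus) for metabolic stability, read by LC-MS, with a stated time of 60 min, at 37 degrees C, tested at 50 uM; on this read-out lower numbers stand for a less stable compound and higher numbers for a more stable compound. Compound 1 and compound 2 share one core and differ only by hydrogen in place of methyl on a saturated chain carbon bound to a carbonyl carbon; that step, no change at the digits printed from compound 2 to compound 1 (within the scatter), left the read-out where it was. Compound 3 carries a different core, and the difference between the two cores is not broken down here; its value stands level with compound 1 and compound 2, all three sitting at the same bottom reading.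

Compound 4 `CC(C)C(=O)OCOC(=O)c1cccc(NC(=O)[C@@H]2C[C@H](SC3=C(C(=O)O)N4C(=O)[C@H]([C@@H](C)O)[C@H]4[C@H]3C)CN2)c1` is the unmeasured partner of compound 3, differing from it by hydrogen in place of methyl on a saturated chain carbon bound to a carbonyl carbon and two saturated chain carbons. Among the measured compounds shown here, this is the same kind of change as the one from compound 2 to compound 1, though not the same: there the carbon bore a carbonyl carbon only, here it bears a carbonyl carbon and two saturated chain carbons. Since the earlier step of no change at the digits printed from compound 2 to compound 1 (within the scatter) showed nothing and compound 3 already reads 0%, the step from compound 3 to compound 4 is expected to be no change at the digits printed from compound 3 to compound 4 (within the scatter). Compound 4 is therefore estimated at 0%, between 0% and 8%.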

Compound 4, percent of the compound remaining: 0%
The estimate for compound 4 equals the measured number at the digits printed; measured number inside the range.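

In this assay, putting isopropyl in place of tert-butyl gave no change at the digits printed from compound 3 to compound 4 (within the scatter). Hydrogen in place of methyl therefore reads alike on the two cores, although the carbon carrying it is not quite the same in the two cases: the same change on two cores in this assay, no change at the digits printed (within the scatter) from compound 2 to compound 1 and no change at the digits printed (within the scatter) from compound 3 to compound 4, 0 percentage points apart, within the scatter of two such steps All four compounds stand at the same bottom reading, however, so this agreement shows only that the change did not lift a compound off that reading on either core, and it does not show that the change would carry over with the same size to a compound reading higher.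

The compounds shown leave open whether a longer chain or an amine in place of the isopropyl of compound 4 would give a reading above the bottom in this assay. They also leave open how hydrogen in place of methyl behaves where the read-out has room to move in either direction.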